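Adding One Fluoro to Compound 2

A few compounds are considered here, and "the series" means these few. Any claim that something is new, unique, unknown or untested is made for them only; others in the source may bear on it.

Among the compounds with values here, in an ADME assay on the whole organism (Rattus norvegicus, strain Sprague-Dawley) for pharmacokinetics, using cassette dosing, at a dose of 0.5 mg/kg by the intravenous route (on this read-out higher numbers stand for fast clearance and lower numbers for slow clearance), compound 1 `O=C(Nc1ccc2[nH]c(=O)oc2c1)C(=O)N1CCN(c2ccc(Cl)cc2)CC1` gives 7.2 mL/min/kg and compound 2 `O=C(Nc1ccc2[nH]c(=O)oc2c1)C(=O)N1CCN(c2ccc(C(F)(F)F)cc2)CC1` gives 15.1 mL/min/kg as the higher of the two numbers so far. Within the data shown here, the one measured step is a 2.1-fold higher number from compound 1 to compound 2 (0.32 log units; beyond the scatter) and it comes with trifluoromethyl in place of chloro on an aromatic carbon.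

Compound 3 `O=C(Nc1ccc2[nH]c(=O)oc2c1)C(=O)N1CCN(c2ccc(C(F)(F)F)c(F)c2)CC1` differs from compound 2 by a single change (fluoro in place of hydrogen on an aromatic carbon), with fluoro in place of hydrogen on an aromatic carbon, ortho to a trifluoromethyl group. Among the measured compounds shown here, no measured step adds a fluoro, so the earlier swap of a different group is only a loose guide, and it was modest in size. No step beyond the scatter is therefore expected in this assay for this change. The estimated step is a 1.1-fold lower number from compound 2 to compound 3 (0.03 log units; within the scatter) and its direction remains uncertain. The estimate for compound 3 is 14 mL/min/kg (expected range 7.5 mL/min/kg to 27 mL/min/kg).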

Compound 3, clearance: 5.6 mL/min/kg
Beside the measured number, compound 3's estimate is 2.5-fold (0.40 log units) above it, outside the stated range (below it).
By their numbers in this assay, from the lowest: compounds 3 and 1 (each within the scatter of the next); then compound 2.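

In this assay, putting a single fluoro on the aromatic carbon ortho to a trifluoromethyl group gives a 2.7-fold lower number from compound 2 to compound 3 (0.43 log units; beyond the scatter), so this position matters for clearance even though the change adds only one heavy atom. Within the data shown here, the only earlier step replaced chloro with trifluoromethyl and raised the number, whereas this one keeps trifluoromethyl in place and lowers it, towards slower clearance. No measurement available here explains why this fluoro has this effect.

The compounds shown leave open whether a methyl group or a nitrile on the same aromatic carbon would lower the number as fluoro does. They also leave open whether fluoro would give a similar step in a compound that carries chloro instead of trifluoromethyl.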